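Tert-Butyl for Phenyl on a Platelet Inhibitor Core

The compounds below may be only part of what the source reports. "The series", "measured", "known", "first", "only" and "open" are said of these compounds alone.

For the measured compounds named here, compound 1 `O=c1cc(N2CCNCC2)nc2sc(-c3ccccc3)nn12` holds the lowest of the two numbers so far in a functional assay on cells (Platelet) for inhibition (a lower number here means a stronger inhibitor, a higher number a weaker inhibitor), giving 3000 nM. Compound 2 `CCc1nn2c(=O)c(F)c(N3CCNCC3)nc2s1` gives 8300 nM in this assay, a gap beyond the usual scatter, though compound 2 differs from compound 1 in more than one place. Compound 3 `CC(C)(C)c1nn2c(=O)cc(N3CCNCC3)nc2s1` carries tert-butyl in place of phenyl on an aromatic carbon. Going by the values given here, no step between measured compounds isolates this single change, so the expectation rests on the two values alone. A modest weakening is expected, a 1.7-fold higher number from compound 1 to compound 3 (0.22 log units; within the scatter). Compound 3 is accordingly estimated at 5000 nM, within a range from 1500 nM to 15000 nM.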

Compound 3, half-maximal inhibitory concentration: 4000 nM
Compound 3: middle estimate off by 1.3-fold (0.10 log units), on the high side, within the range that was stated.
By their numbers in this assay, from the lowest: compounds 1 and 3 (each within the scatter of the next); then compound 2.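

For the compounds shown here, this is the first step that isolates a single change at this position. On the aromatic carbon next to the ring sulfur, tert-butyl in place of phenyl gives a 1.3-fold higher number from compound 1 to compound 3 (0.12 log units; within the scatter) in this assay and stays within the scatter. A group with no ring therefore reads the same here as the six-membered aromatic ring of carbon only. Nothing available bears on why the two groups read alike. On these data alone, whether an amine, a carboxylic acid or a longer chain on this carbon would read the same remains open.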